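This account rests on a few compounds, and the source may have more. Where it says the series, first, only, none or still open, it means among the compounds named here.

Compound 1, `COc1ccc(S(=O)(=O)Nc2cccc(Br)c2)cc1N1CCNCC1`, gives 1.26 nM in an assay on isolated protein for binding affinity to 5-hydroxytryptamine receptor 6 (Homo sapiens); a higher number here means a weaker inhibitor, a lower number a stronger inhibitor.
Compound 2, `COc1ccc(S(=O)(=O)Nc2cc(Br)cc(Br)c2Br)cc1N1CCNCC1`, gives 2.51 nM in this assay.
Compound 3, `COc1ccc(S(=O)(=O)Nc2cc(Br)cc(Br)c2F)cc1N1CCNCC1`, has not yet been measured in this assay.

For the measured compounds named here, compound 2 stands alongside compound 1 as one of only two numbers so far, and the two cannot be told apart: the step of a 2.0-fold higher number from compound 1 to compound 2 (0.30 log units; within the scatter) lies within the usual scatter of repeated measurements. Going by the values given here, that step added two bromo groups to the ring on the sulfonamide nitrogen, including the one that compound 3 now exchanges.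

Compound 3 differs from compound 2 by fluoro in place of bromo on an aromatic carbon. Among the compounds with values here, only the step from compound 1 to compound 2 bears on this position, and it showed that putting a bromo group there, together with a second one, changed the number by no more than the scatter. Swapping that bromo for a fluoro is a smaller change than adding it, so no step beyond the scatter is expected in this assay for compound 3, in either direction.

Compound 3 is therefore expected to give about 2.5 nM in this assay, between 1 nM and 6 nM, a step of a 1.0-fold lower number from compound 2 to compound 3 (0.00 log units; within the scatter) that is estimated to stay within the scatter.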

Compound 3, inhibition constant: 2.51 nM
For compound 3 the middle estimate is 1.0-fold (0.00 log units) below the measured one; measured number inside the range.
By their numbers in this assay, from the lowest: compounds 1, 2 and 3 (each within the scatter of the next).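

In this assay, the exchange of bromo for fluoro on this aromatic carbon, ortho to a bromo group and para to a bromo group, gives no change at the digits printed from compound 2 to compound 3 (within the scatter). For the compounds shown here, this is the first reading of this position on its own, since the earlier step added two bromo groups at once, and it shows that a fluorine and a bromine at this place cannot be told apart here. Going by these compounds alone, the wider change gives a 2.0-fold higher number from compound 1 to compound 3 (0.30 log units; within the scatter), so the 3,5-dibromo-2-fluorophenyl group, like the 2,3,5-tribromophenyl group, stays within the scatter of the single 3-bromophenyl group, and no evidence at hand explains this flat result.

The compounds shown leave open whether this position accepts only halogens, or whether a methoxy group, an amine or a carboxylic acid in the same place would also leave the number within the scatter. They also leave open what the bromo group para to this position contributes by itself, as it enters together with the group at this position and is never seen alone.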